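Phenoxy on the Sulfonyl Sulfur of Compound 1

The compounds below may be only part of what the source reports. "The series", "measured", "known", "first", "only" and "open" are said of these compounds alone.

Measured compounds:
- compound 1 `CC(C)NS(=O)(=O)c1ccc2c(c1)C(n1ccccc1=O)=CC(C)(C)O2` — 676 nM
- compound 2 `CC1(C)C=C(n2ccccc2=O)c2cc(S(=O)(=O)Nc3ccccc3)ccc2O1` — 3.09 nM; 2 nM (2 entries)
- compound 3 `CN(c1ccccc1)S(=O)(=O)c1ccc2c(c1)C(n1ccccc1=O)=CC(C)(C)O2` — 1.74 nM

In a functional assay with Rattus norvegicus as the target (a lower number here means that less compound is needed, a higher number that more compound is needed for the effect), compound 1 gives 676 nM, the highest of the two single numbers, with compound 3 the nearest at 1.74 nM. Compound 2 carries a phenylamino group on the sulfonyl sulfur and gives 3.09 nM; 2 nM (2 entries), which the repeated entries the several entries of compound 2 in this assay, 3.09 nM; 2 nM (2 entries) show to be consistent.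

Compound 4 `CC1(C)C=C(n2ccccc2=O)c2cc(S(=O)(=O)Oc3ccccc3)ccc2O1` is not yet measured. It differs from compound 1 in one place: phenoxy in place of isopropylamino on a sulfonyl sulfur.

Among the compounds with values here, the one measured step that bears on this change is a 390-fold lower number from compound 1 to compound 3 (2.59 log units; beyond the scatter), where a phenyl-bearing group replaced isopropylamino on the same sulfonyl sulfur. Compound 2, with phenylamino in that place, stands at the same low level as compound 3. Within the data shown here, both phenyl-bearing compounds sit far below compound 1, and compound 4 likewise carries a phenyl ring there, though joined through oxygen rather than nitrogen, a connection for which no measured compound gives a step.

Compound 4 is therefore expected to give a clearly lower number than compound 1, with the step of a 45-fold lower number from compound 1 to compound 4 (1.65 log units; beyond the scatter) estimated as large but not assumed to match compound 3 fully. The expected value for compound 4 in this assay is 15 nM, within a range from 3 nM to 150 nM.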

Compound 4, half-maximal effective concentration: 2.51 nM
The estimate for compound 4 lay 6.0-fold (0.78 log units) above the measured number; the whole stated range lies above it.
By their numbers in this assay, from the lowest: compounds 3 and 4 (each within the scatter of the next); then compound 1.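

In this assay, within the data shown here, the change to phenoxy gives a 270-fold lower number from compound 1 to compound 4 (2.43 log units; beyond the scatter), so the large drop seen with a phenyl-bearing group on the sulfonyl sulfur also holds when the ring is joined through oxygen, a link the earlier compounds did not cover. The comparison with the tertiary sulfonamide gives a 1.4-fold higher number from compound 3 to compound 4 (0.16 log units; within the scatter), so phenoxy and methyl(phenyl)amino cannot be told apart in this assay. Compound 2, with phenylamino in the same place, has printed values close to that of compound 4, so among these three compounds the low level appears with the phenyl ring joined through oxygen, through nitrogen bearing a methyl group or through nitrogen bearing a hydrogen, and repeated readings support the level for phenylamino: the several entries of compound 2 in this assay, 3.09 nM; 2 nM (2 entries)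

On these data alone, whether the aromatic ring itself is required remains open, and a cyclohexyloxy or a methoxy group on the sulfonyl sulfur would address that question. As far as these compounds go, it is also open how far the low level would survive a benzyloxy group, with its added carbon, or a chlorine atom or a carboxylic acid on the phenyl ring.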